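A few compounds are considered here, and "the series" means these few. Any claim that something is new, unique, unknown or untested is made for them only; others in the source may bear on it.

Three compounds have been measured in a functional assay on MCF7 cells (Homo sapiens) for cytotoxicity, read by MTT assay, with a stated time of 72 h; a lower number here means a stronger inhibitor, a higher number a weaker inhibitor:

compound 1 `O=C(Nc1ccc(Oc2ccnc3[nH]ccc23)cc1)c1cc(-c2ccc(F)cc2)ncn1` gave 15900 nM;
compound 2 `O=C(Nc1ccc(Oc2ccnc3[nH]ccc23)cc1)c1cc(-c2ccc(Cl)cc2)ncn1` gave 7770 nM;
compound 3 `O=C(Nc1ccc(Oc2ccnc3[nH]ccc23)c(F)c1)c1cc(-c2ccc(F)cc2)ncn1` gave no single number and was recorded as "not active" (no number reported).

Compound 2 differs from compound 1 by chloro in place of fluoro on an aromatic carbon, and in this assay that step reads a 2.0-fold lower number from compound 1 to compound 2 (0.31 log units; beyond the scatter). Among the compounds with values here, compound 3 differs from compound 1 by fluoro in place of hydrogen on an aromatic carbon; with no number for compound 3, the size of that step cannot be given, only that the shared core of compound 1 carrying this extra fluoro lost measurable activity in this assay.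

Compound 4 `O=C(Nc1ccc(Oc2ccnc3[nH]ccc23)c(F)c1)c1cc(-c2ccc(Cl)cc2)ncn1` has not yet been measured. It differs from compound 3 by chloro in place of fluoro on an aromatic carbon, the same change as from compound 1 to compound 2, set on the same place in both pairs. The step from compound 3 to compound 4 in this assay cannot be sized against a measured starting value; if it behaved as the earlier one, it would be expected to be modest. Compound 4 is therefore expected to stay weak, with an estimate of about 30000 nM, from 8000 nM to 120000 nM, because compound 1 gave 15900 nM and compound 3 was recorded as "not active" (no number reported).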

Compound 4, half-maximal inhibitory concentration: 26900 nM
Beside the measured number, compound 4's estimate is 1.1-fold (0.05 log units) above it; low and high end bracket the measured number.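

In this assay, fluoro in place of hydrogen on an aromatic carbon reads a 3.5-fold higher number from compound 2 to compound 4 (0.54 log units; beyond the scatter), and the same change on the core of compound 1 gave compound 3, recorded as "not active", so on both cores the change goes with a weaker result. From the compounds shown here alone, the steps that start or end at compound 3 cannot be read, as it has no number; the size of the fluoro change therefore cannot be compared between the two cores, and it stays unknown whether chloro in place of fluoro carries the same step onto the fluorinated core, though compound 4 does give a number where compound 3 gives none. Nothing given here accounts for this result in either pair.

The compounds shown leave open how the fluorinated core would read with a methoxy group, a nitrile or an amine in place of the chloro. They also leave open whether bromo would continue the step seen from fluoro to chloro.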